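The compounds below may be only part of what the source reports. "The series", "measured", "known", "first", "only" and "open" are said of these compounds alone.

Measured in an ADME assay on L6 cells (Rattus norvegicus) for cytotoxicity, read by fluorescence and resazurin assay, with a stated time of 72 h; on this read-out higher numbers stand for lower toxicity in this test and lower numbers for higher toxicity in this test:

Compound 1 `CC(C)(C)c1ccc(-c2c[nH]cc2C(c2ccc(Cl)cc2Cl)n2ccnc2)cc1`: 22900 nM
Compound 2 `Clc1ccc(C(c2c[nH]cc2-c2ccc(-c3ccccc3)cc2)n2ccnc2)c(Cl)c1`: > 202000 nM (a limit, not a number)

Compound 2 gives no exact number and rests at the limit of > 202000 nM in this assay, at which 1 of the 2 values shown sits. Compound 3 `Clc1ccc(C(c2c[nH]cc2-c2ccc(-c3ccncc3)cc2)n2ccnc2)c(Cl)c1` carries pyridin-4-yl in place of phenyl on an aromatic carbon. Going by the values given here, only one measured step bears on this change, an at least 8.8-fold higher number from compound 1 to compound 2 (0.94 log units; beyond the scatter). That step brought in the phenyl that now leaves, but it says nothing direct about a ring with a hetero atom, so it is a weak guide to size. A modest fall in this assay is expected, or no change that the limit would reveal. The expected change is an at least 1.8-fold lower number from compound 2 to compound 3 (0.26 log units; that floor lies within the scatter). Compound 1 at 22900 nM serves as the low reference for this expectation. Compound 3 is estimated at 110000 nM, with an expected range from 35000 nM to 250000 nM.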

Compound 3, half-maximal cytotoxic concentration: 15500 nM
Compound 3: middle estimate off by 7.1-fold (0.85 log units), on the high side; the measured number lies below the stated range.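

In this assay, going by these compounds alone, the earlier compounds showed only that phenyl, on an aromatic carbon para to a large group, gave a higher number than tert-butyl; the new result shows that one ring nitrogen, in pyridin-4-yl, is enough to remove that gain, with an at least 13-fold lower number from compound 2 to compound 3 (1.11 log units; beyond the scatter). Compound 2 gives no exact number, so this step is a floor: the limit of > 202000 nM in this assay, at which 1 of the 3 values shown sits. Pyridin-4-yl and tert-butyl stand level at this place, with a 1.5-fold lower number from compound 1 to compound 3 (0.17 log units; within the scatter), so among the three groups shown only phenyl gives the higher number.

From the compounds shown here alone, what pyridin-3-yl, or a phenyl carrying an amine or a carboxylic acid, would give at this place stays open. The compounds shown also do not tell why the ring nitrogen has this effect in this test.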